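The source may report more compounds than this note shows. Statements on the series, on what has been measured and on what is new or still open speak of the compounds shown alone.

Of the compounds shown here, three have so far been measured in an assay on HEK293 cells for positive allosteric modulation of metabotropic glutamate receptor 3 (Rattus norvegicus), read by thallium flux, with a stated time of 2.5 min; a lower number here means a smaller maximal response, a higher number a larger maximal response. Compound 1 `CCCC(=O)c1ccc(OCCCCOc2ccc(F)c(C(=O)O)c2)c(C)c1O` gives 56.9% in this assay and stands highest of the three numbers. Compound 2 `Cc1cc(C(=O)O)ccc1OCCCCOc1ccc(C(=O)CC2CCCC2)c(O)c1C` gives 28.4% in this assay, a number that lies beyond the scatter below the value of compound 1. Compound 3 `Cc1c(OCCCCOc2cccc(C(=O)O)c2)ccc(C(=O)CC2CCCC2)c1C` gives 16.5% in this assay, the lowest of the three and likewise beyond the scatter from compound 1. None of these three pairs differs in only one place, so no single structural step can be read from the measured set.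

Compound 4 `Cc1c(OCCCCOc2ccc(F)c(C(=O)O)c2)ccc(C(=O)CC(C)C)c1O` has not yet been measured. It differs from compound 1 by methyl in place of hydrogen on a saturated chain carbon bound to two saturated chain carbons. For the measured compounds named here, the measured compounds show no step of this kind. The expectation therefore rests on compound 1 alone, and a small change, likely within the scatter, is expected in this assay. Compound 4 is therefore estimated to give 50% in this assay, with a range from 30% to 70%. This estimate corresponds to an expected a number 6.9 percentage points lower from compound 1 to compound 4 (within the scatter).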

Compound 4, largest response reached (reported as percent of maximum), in percent of the reference or control that the assay uses: 81.7%
Beside the measured number, compound 4's estimate is 31.7 percentage points below it; measured number above the stated range.
By their numbers in this assay, from the lowest: compound 3; then compound 2; then compound 1; then compound 4.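

In this assay, replacing propylcarbonyl with isobutylcarbonyl gives a number 24.8 percentage points higher from compound 1 to compound 4 (beyond the scatter). This saturated chain carbon bound to two saturated chain carbons is therefore a place where a single added methyl changes the maximal response, and here the change is upward. It is the only one-place step in the set, so it is the first direct reading of any structural change, and no information shown here accounts for the rise.

The compounds shown leave open whether an ethyl group in place of the new methyl, or an amine or hydroxyl group on the same carbon, would raise the response further or reduce it. They also leave open whether the same step gives a similar rise when the fluoro group on the shared core is replaced by hydrogen.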